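The compounds below may be only part of what the source reports. "The series", "measured", "known", "first", "only" and "open" are said of these compounds alone.

Measured so far in a functional assay on HepG2 cells (Homo sapiens) for inhibition, read by MTT assay, with a stated time of 24 h; a higher number here means a weaker inhibitor of growth, a lower number a stronger inhibitor of growth:
Compound 1 `COc1ccccc1C(=O)n1c(-c2cn(C)c3ccccc23)nc2ccccc21` gives 31800 nM
Compound 2 `COc1ccc(C(=O)n2c(-c3cn(C)c4ccccc34)nc3ccccc32)cc1OC` gives 8400 nM
Compound 3 `COc1ccc2c(c1)c(-c1nc3ccccc3n1C(=O)c1ccccc1OC)cn2C` gives 23600 nM

Compound 3 holds the second highest of these three numbers, and a 1.3-fold lower number from compound 1 to compound 3 (0.13 log units; within the scatter) is a step for methoxy in place of hydrogen on an aromatic carbon. Compound 4 `COc1ccc2c(c1)c(-c1nc3ccccc3n1C(=O)c1ccc(OC)c(OC)c1)cn2C` departs from compound 3 at one place, (3,4-dimethoxyphenyl in place of 2-methoxyphenyl on a carbonyl carbon), with 3,4-dimethoxyphenyl in place of 2-methoxyphenyl on a carbonyl carbon. That same exchange has been measured only once, as a 3.8-fold lower number from compound 1 to compound 2 (0.58 log units; beyond the scatter), so a modest drop of similar size is expected, resting on that single example. The expected change is a 3.7-fold lower number from compound 3 to compound 4 (0.57 log units; beyond the scatter) in this estimate. Compound 4 is therefore estimated at 6300 nM, within a range of 2800 nM to 14000 nM when measured.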

Compound 4, concentration for 50% growth inhibition: 5100 nM
Compound 4: middle estimate off by 1.2-fold (0.09 log units), on the high side; the range from low to high includes it.
By their numbers in this assay, from the lowest: compounds 4 and 2 (each within the scatter of the next); then compounds 3 and 1 (each within the scatter of the next).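

In this assay, the exchange of 2-methoxyphenyl for 3,4-dimethoxyphenyl on a carbonyl carbon now holds on a second core (a 4.6-fold lower number from compound 3 to compound 4 (0.67 log units; beyond the scatter)), and its size is matched on both cores: (the same change on two cores in this assay, a 3.8-fold lower number (0.58 log units; beyond the scatter) from compound 1 to compound 2 and a 4.6-fold lower number (0.67 log units; beyond the scatter) from compound 3 to compound 4, 1.2-fold (0.09 log units) apart, within the scatter of two such steps). Methoxy in place of hydrogen on an aromatic carbon stays small with 3,4-dimethoxyphenyl present (a 1.6-fold lower number from compound 2 to compound 4 (0.22 log units; within the scatter)), as it was with 2-methoxyphenyl: (the same change on two cores in this assay, a 1.3-fold lower number (0.13 log units; within the scatter) from compound 1 to compound 3 and a 1.6-fold lower number (0.22 log units; within the scatter) from compound 2 to compound 4, 1.2-fold (0.09 log units) apart, within the scatter of two such steps). Across these four compounds, neither change alters the size of the other.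

The compounds shown leave open whether the lower number requires both methoxy groups of 3,4-dimethoxyphenyl. They also leave open how an amine or a carboxylic acid in place of those methoxy groups would read.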